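The source may report more compounds than this note shows. Statements on the series, on what has been measured and on what is new or still open speak of the compounds shown alone.

In a functional assay on HCT-116 cells (Homo sapiens) for antiproliferative activity, read by CCK-8 assay, with a stated time of 72 h (on this read-out higher numbers stand for weaker inhibition and lower numbers for stronger inhibition), three compounds sharing one core have been measured, and they differ in the substituted phenyl group carried on a nitrogen. Compound 1 `Cc1cc(Nc2cc(N3CCN(C)CC3)nc(Nc3ccc(S(N)(=O)=O)cc3)n2)n[nH]1` gives 12200 nM, compound 2 `Cc1cc(Nc2cc(N3CCN(C)CC3)nc(Nc3ccc(Cl)cc3)n2)n[nH]1` gives 1370 nM, and compound 3 `Cc1cc(Nc2cc(N3CCN(C)CC3)nc(Nc3cccc([N+](=O)[O-])c3)n2)n[nH]1` gives 1820 nM. Compound 3 holds the middle of these three numbers in name only: a 1.3-fold higher number from compound 2 to compound 3 (0.12 log units; within the scatter), while a 6.7-fold lower number from compound 1 to compound 3 (0.83 log units; beyond the scatter).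

The next structure, compound 4 `Cc1cc(Nc2cc(N3CCN(C)CC3)nc(Nc3cccc(Cl)c3)n2)n[nH]1`, alters compound 3 in a single place: chloro in place of nitro on an aromatic carbon. Chloro takes the place of nitro on an aromatic carbon, so 3-nitrophenyl becomes 3-chlorophenyl.

For the measured compounds named here, two measured steps bear on this change. The swap of sulfamoyl for chloro gave an 8.9-fold lower number from compound 1 to compound 2 (0.95 log units; beyond the scatter), a modest step, but the group leaving there is not nitro, so it offers only weak guidance. Closer is the swap of 4-chlorophenyl for 3-nitrophenyl, which gave a 1.3-fold higher number from compound 2 to compound 3 (0.12 log units; within the scatter). So far, then, a chlorophenyl and a nitrophenyl group have given values within the scatter of each other. Going by the values given here, no measured compound yet carries 3-chlorophenyl, so the expectation remains uncertain.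

In this assay, no change beyond the scatter is expected, and the estimated step is a 1.2-fold lower number from compound 3 to compound 4 (0.08 log units; within the scatter). Compound 4 is estimated at 1500 nM, with an expected range from 700 nM to 3200 nM.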

Compound 4, half-maximal inhibitory concentration: 736 nM
For compound 4 the middle estimate is 2.0-fold (0.31 log units) above the measured one; the measured number falls inside the stated range.
By their numbers in this assay, from the lowest: compounds 4, 2 and 3 (each within the scatter of the next, the first and the last beyond it); then compound 1.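

In this assay, for the compounds shown here, chloro in place of nitro on the same aromatic carbon gives a 2.5-fold lower number from compound 3 to compound 4 (0.39 log units; beyond the scatter), and this is the first comparison of the two groups at one place on the ring; the earlier comparison of 4-chlorophenyl with 3-nitrophenyl changed the place as well as the group and stayed within the scatter. The two chlorophenyl compounds cannot be told apart (a 1.9-fold lower number from compound 2 to compound 4 (0.27 log units; within the scatter)), so these data do not show that the place of the chloro matters, whereas 3-chlorophenyl against 4-sulfamoylphenyl gives a large step (a 17-fold lower number from compound 1 to compound 4 (1.22 log units; beyond the scatter)). Nothing measured here accounts for the size of any of these steps.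

The compounds shown leave open how other groups on this aromatic carbon would compare with chloro, such as fluoro, bromo, methyl, an amine or a carboxylic acid. As far as these compounds go, they also keep the rest of the shared core unchanged, so it remains open whether the step from nitro to chloro would keep its size on a different core.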